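From fluoro to methyl on a shared core

The source may hold more compounds than are shown below. What is called first, only, known or untested is meant among the compounds shown, and "the series" means these compounds.

Compound 1 `COc1ccc(-c2[nH]c3cc(F)ccc3c2C=O)cc1` gives 43 nM
Compound 2 `COc1ccc(-c2[nH]c3ccc(F)cc3c2C=O)cc1` gives 240 nM

Both values come from a functional assay on MCF7 cells (Homo sapiens) for antiproliferative activity, with a stated time of 5 days; a higher number here means a weaker inhibitor, a lower number a stronger inhibitor. Compound 2 stands at the higher of the two numbers, and the gap down to compound 1 lies beyond the scatter. The two compounds differ only in where the fluoro sits on the shared core. Compound 3 `COc1ccc(-c2[nH]c3ccc(C)cc3c2C=O)cc1` follows compound 2 but carries methyl in place of fluoro on an aromatic carbon. For the measured compounds named here, no measured pair shows this exchange, so the expectation is only tentative. In this assay, a small step towards a stronger inhibitor is expected, and it may not clear the scatter. The range is kept wide, as compound 2 at 240 nM and compound 1 at 43 nM show how far the numbers can move on this core. The estimate means an expected 1.8-fold lower number from compound 2 to compound 3 (0.27 log units; within the scatter). For compound 3 the estimated value is 130 nM, with an expected range of 35 nM to 500 nM.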

Compound 3, half-maximal inhibitory concentration: 140 nM
Beside the measured number, compound 3's estimate is 1.1-fold (0.03 log units) below it; the measured number falls inside the stated range.
By their numbers in this assay, from the lowest: compound 1; then compounds 3 and 2 (each within the scatter of the next).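

In this assay, methyl in place of fluoro on an aromatic carbon gives a 1.7-fold lower number from compound 2 to compound 3 (0.23 log units; within the scatter), so at this place on the shared core the two groups cannot be told apart. The earlier pair showed only that moving the fluoro opens a gap beyond the scatter, with compound 2 at 240 nM and compound 1 at 43 nM; this step adds that, at the place the fluoro holds in compound 2, methyl reads the same as fluoro. Nothing available bears on why the two groups read alike.

The compounds shown leave open how an amine or a carboxylic acid would read at this place. They also leave open whether methyl would match fluoro at the place the fluoro holds in compound 1.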